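The source may report more compounds than this note shows. Statements on the series, on what has been measured and on what is new or still open speak of the compounds shown alone.

Measured in a functional assay (brain) for inhibition, with Rattus norvegicus as the target; a higher number here means a weaker inhibitor, a lower number a stronger inhibitor:
compound 1 `Cc1c(C)c2c(c(C)c1O)C(CN1CCCCC1)C(C)(C)O2`: 400 nM
compound 2 `Cc1c(C)c2c(c(C)c1O)C(CNC(C)C)C(C)(C)O2`: 1400 nM
compound 3 `Cc1c(C)c2c(c(C)c1O)C(CN1CCN(C)CC1)C(C)(C)O2`: 450 nM; 400 nM; 400 nM (3 entries)

Of the two single numbers in this assay, compound 2 holds the higher, and compound 1 is its nearest neighbour. Compound 3 has repeated entries instead: the several entries of compound 3 in this assay, 450 nM; 400 nM; 400 nM (3 entries). The next compound is compound 4 `Cc1c(C)c2c(c(C)c1O)C(CN(C)C)C(C)(C)O2`, with the change dimethylamino in place of isopropylamino on a saturated chain carbon bound to a saturated ring carbon. Among the compounds with values here, the one measured step bearing on this is a 3.5-fold higher number from compound 1 to compound 2 (0.54 log units; beyond the scatter), where isopropylamino replaces piperidin-1-yl. Removing isopropylamino is therefore expected to lower the number, by a similar or smaller amount. The expected step is a 2.2-fold lower number from compound 2 to compound 4 (0.33 log units; beyond the scatter). The estimated value for compound 4 is 650 nM, with an expected range of 300 nM to 1400 nM.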

Compound 4, half-maximal inhibitory concentration: 700 nM
Beside the measured number, compound 4's estimate is 1.1-fold (0.03 log units) below it; low and high end bracket the measured number.
By their numbers in this assay, from the lowest: compounds 1, 4 and 2 (each within the scatter of the next, the first and the last beyond it).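

In this assay, dimethylamino on a saturated chain carbon bound to a saturated ring carbon cannot be told apart from either earlier amine: a 2.0-fold lower number from compound 2 to compound 4 (0.30 log units; within the scatter), and a 1.8-fold higher number from compound 1 to compound 4 (0.24 log units; within the scatter). Compound 4 thus lies within the scatter of two compounds that differ beyond it, and exchanging isopropylamino for dimethylamino, with one hydrogen-bond donor fewer, gives no readable change. Nothing measured here accounts for this result. Open, on these data alone, is how a primary amine, a morpholine or a non-basic amide would read at this place.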